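The source may report more compounds than this note shows. Statements on the series, on what has been measured and on what is new or still open speak of the compounds shown alone.

Compound 1, `CCCCC[Se]c1nc(NCc2ccc(SC)cc2)c2ccccc2n1`, gives in a functional assay on CCRF-CEM cells (Homo sapiens) for cytotoxicity, read by MTT assay, with a stated time of 72 h; on this read-out higher numbers stand for lower toxicity in this test and lower numbers for higher toxicity in this test > 100000 nM, which is a limit of the assay.
Compound 2, `CSc1ccc(CNc2nc([SeH])nc3ccccc23)cc1`, gives in this assay > 100000 nM, again a limit.
Compound 3, `CSc1nc(NCCCc2ccccc2)c2ccccc2n1`, gives in this assay > 100000 nM, also a limit.

Compound 3 thus stands at the limit of > 100000 nM in this assay, at which 3 of the 3 values shown sit; no number separates it from compound 1 or compound 2. Within the data shown here, the only step between measured compounds is a step that the two limits leave unreadable from compound 1 to compound 2, and it gives no readable size. Compound 4, `CSc1nc(NCCCCc2ccccc2)c2ccccc2n1`, differs from compound 3 by benzyl in place of phenyl on a saturated chain carbon, three bonds along the chain from a nitrogen on an aromatic ring. Among the measured compounds shown here, no measured step bears on this change, so for compound 4 in this assay a step of a number no higher from compound 3 to compound 4 (the limit leaves the size open) is expected, none beyond the scatter. Compound 4 is therefore estimated at 100000 nM, between 30000 nM and 300000 nM, and most likely it too is reported only as a limit.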

Compound 4, concentration lethal to 50% of the cells: > 100000 nM
Compound 4 gave a limit, no number; the forecaster's own chance of this, stated with the estimate: 85%; the middle value lies on the limit itself.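

Among these compounds, compound 3 and compound 4 both stand as limits, not numbers, and no step between them can be read in this assay at all. The compounds shown leave open how toxic any of them is, and whether benzyl in place of phenyl changes that.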